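The compounds below may be only part of what the source reports. "The series", "measured", "known", "first", "only" and "open" are said of these compounds alone.

In a functional assay on A549 cells (Homo sapiens) for cytotoxicity, read by MTT assay, with a stated time of 48 h (on this read-out higher numbers stand for weaker inhibition and lower numbers for stronger inhibition), compound 1 `O=C(O)CN1C(=O)/C(=C/c2nc3ccc(Cl)cc3n2Cc2ccccc2F)SC1=S` gives 26900 nM as a true number. Compound 2 `O=C(O)CN1C(=O)/C(=C/c2nc3ccc(F)cc3n2Cc2ccccc2F)SC1=S` reads > 50000 nM in this assay and this is a limit, not a number. Compound 2 therefore has no exact place on the scale. In compound 3 `COc1ccc2nc(/C=C3\SC(=S)N(CC(=O)O)C3=O)n(Cc3ccccc3F)c2c1` the shared core stays and methoxy in place of fluoro on an aromatic carbon is the whole change, methoxy in place of fluoro on an aromatic carbon. Within the data shown here, the one measured step that bears on this is an at least 1.8-fold higher number from compound 1 to compound 2 (0.26 log units; that floor lies within the scatter) for fluoro in place of chloro on an aromatic carbon, and this floor does not show the true size of that step. No step beyond the scatter is therefore expected in this assay and no direction can be argued. With the limit of > 50000 nM in this assay, at which 1 of the 2 values shown sits, in mind, another limit reading is possible. The estimate implies an at least 1.1-fold lower number from compound 2 to compound 3 (0.04 log units; that floor lies within the scatter) as the expected step. For compound 3 the expected value is 45000 nM with an estimated range from 18000 nM to 100000 nM as a rough guide.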

Compound 3, half-maximal inhibitory concentration: 36200 nM
Estimate against measurement, compound 3: 1.2-fold (0.09 log units) above, within the range that was stated.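

Compound 3 gives a true number on this aromatic carbon, where compound 2 gave only a limit, so a substituent here can now be compared with chloro at both ends of the step. In this assay that comparison reads a 1.3-fold higher number from compound 1 to compound 3 (0.13 log units; within the scatter), so methoxy and chloro cannot be told apart at this place. The other reading is an at least 1.3-fold lower number from compound 2 to compound 3 (0.14 log units; that floor lies within the scatter), and it is only a floor, because compound 2 stands as a limit: the limit of > 50000 nM in this assay, at which 1 of the 3 values shown sits.

Going by these compounds, it remains open whether an amine or a carboxylic acid on this carbon would move the reading beyond the scatter. On these data alone, it is also open whether a longer chain, such as ethoxy in place of methoxy, would do so.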